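Arylalkenyl arm variation on the tetrahydropyranyl methanol series

A few compounds are considered here, and "the series" means these few. Any claim that something is new, unique, unknown or untested is made for them only; others in the source may bear on it.

Three compounds of the series have numbers in a functional assay on HeLa cells (Homo sapiens) for cytotoxicity, read by WST assay, with a stated time of 48 h; on this read-out lower numbers stand for stronger inhibition and higher numbers for weaker inhibition. Compound 1 `COc1cccc(/C=C/C[C@@H]2C[C@@H]([C@@H](O)c3ccc(OC)c(OC)c3)CO[C@H]2c2ccc(OC)c(OC)c2)c1` gives 16400 nM. Compound 2 `Cc1ccc(/C=C/C[C@H]2C[C@@H]([C@@H](O)c3ccccc3)CO[C@@H]2c2ccccc2)cc1C` gives 10000 nM, the lowest of the three, with compound 1 within the scatter of it and compound 3 beyond. Among the compounds with values here, compound 3 `COc1ccc(CCC[C@@H]2C[C@@H]([C@@H](O)c3ccc(OC)c(OC)c3)CO[C@H]2c2ccc(OC)c(OC)c2)cc1OC` gives 35700 nM; the one single-point step on record, a 2.2-fold higher number from compound 1 to compound 3 (0.34 log units; beyond the scatter), exchanges 2-(3,4-dimethoxyphenyl)ethyl for 2-(3-methoxyphenyl)ethenyl on a saturated chain carbon bound to a saturated ring carbon, and it is modest in size.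

Compound 4 `Oc1cccc(/C=C/C[C@H]2C[C@@H]([C@@H](O)c3ccccc3)CO[C@@H]2c2ccccc2)c1` is not yet measured. It differs from compound 2 as follows: 3-hydroxyphenyl in place of 3,4-dimethylphenyl on a double-bonded chain carbon bound to a double-bonded chain carbon. The step from compound 1 to compound 3 touches the same arm of the core and moved this assay only modestly, so a change of the aryl substituents on that arm is expected to move this assay little; the step is expected to be a 1.2-fold higher number from compound 2 to compound 4 (0.08 log units; within the scatter), not clearly beyond the scatter in either direction. For compound 4 the estimate in this assay is 12000 nM, with a range from 5000 nM to 30000 nM.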

Compound 4, half-maximal inhibitory concentration: 18600 nM
Compound 4: middle estimate off by 1.6-fold (0.19 log units), on the low side, and the stated range covers the measured number.
By their numbers in this assay, from the lowest: compounds 2, 1, 4 and 3 (each within the scatter of the next, the first and the last beyond it).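

In this assay, exchanging 3,4-dimethylphenyl for 3-hydroxyphenyl on a double-bonded chain carbon bound to a double-bonded chain carbon gives a 1.9-fold higher number from compound 2 to compound 4 (0.27 log units; within the scatter), so on this core a hydrogen-bond donor and acceptor enter the arm without a step beyond the scatter. Unlike a 2.2-fold higher number from compound 1 to compound 3 (0.34 log units; beyond the scatter), which alters the link and the aryl substituents together, this step keeps the ethenyl link and changes only the aryl group. No evidence on hand bears on the reason for this result.

Open, on these data alone, is whether the same exchange gives a similar step on the core of compound 1, which carries dimethoxyphenyl groups. As far as these compounds go, an aminophenyl or carboxyphenyl group at this place, or a longer chain in the arm, also remains untested in these compounds.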